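The source may hold more compounds than are shown below. What is called first, only, known or untested is meant among the compounds shown, and "the series" means these compounds.

In an ADME assay on HEK293 cells (Homo sapiens) for inhibition, read by MTT assay, with a stated time of 3 days (on this read-out lower numbers stand for stronger inhibition and higher numbers for weaker inhibition), compound 1 (`C=CCOc1cc(/C=C\c2cc(OC)c(OC)c(OC)c2)ccc1OC`) gives 43500 nM and compound 2 (`COCOc1cccc(/C=C/CCCOc2cc(/C=C\c3cc(OC)c(OC)c(OC)c3)ccc2OC)c1`) gives 30000 nM. These two numbers lie within the usual scatter of each other, so compound 2 stands level with compound 1 on the only data available. Compound 3 (`COc1ccc(/C=C\c2cc(OC)c(OC)c(OC)c2)cc1OCCC/C=C/c1ccc(F)cc1`) keeps the rest of compound 2 and differs from it at one place: 4-fluorophenyl in place of 3-(methoxymethoxy)phenyl on a double-bonded chain carbon bound to a double-bonded chain carbon. In words, 4-fluorophenyl stands in place of 3-(methoxymethoxy)phenyl on a double-bonded chain carbon bound to a double-bonded chain carbon. Going by the values given here, no measured pair isolates this change, so the expectation rests on compound 2 at 30000 nM. The expected step is a 1.1-fold lower number from compound 2 to compound 3 (0.03 log units; within the scatter), which is none beyond the scatter in this assay, and no direction is favoured. Compound 3 is estimated at 28000 nM, with an expected range from 11000 nM to 70000 nM.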

Compound 3, half-maximal inhibitory concentration: 115000 nM
Beside the measured number, compound 3's estimate is 4.1-fold (0.61 log units) below it, and the stated range ends below it.
By their numbers in this assay, from the lowest: compounds 2 and 1 (each within the scatter of the next); then compound 3.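

In this assay, this place on the chain proves sensitive to the change: 4-fluorophenyl in place of 3-(methoxymethoxy)phenyl on a double-bonded chain carbon bound to a double-bonded chain carbon gives a 3.8-fold higher number from compound 2 to compound 3 (0.58 log units; beyond the scatter) and so weaker inhibition, a separation that compound 1 and compound 2, level with each other, did not show. Set against the shorter end group, 4-(4-fluorophenyl)but-3-en-1-yl in place of vinyl on a saturated chain carbon bound to an oxygen on an aromatic ring gives a 2.6-fold higher number from compound 1 to compound 3 (0.42 log units; beyond the scatter) and also weakens inhibition. Nothing measured here offers an explanation for either step.

On these data alone, whether the loss goes with the fluorine or with the removal of the methoxymethoxy group remains open. A plain phenyl or a 3-hydroxyphenyl at the same place would help to separate the two.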